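This account rests on a few compounds, and the source may have more. Where it says the series, first, only, none or still open, it means among the compounds named here.

Measured so far in a functional assay on SPCA2 cells (Homo sapiens) for cytotoxicity, read by MTT assay, with a stated time of 2 days; a lower number here means a stronger inhibitor, a higher number a weaker inhibitor:

- Compound 1 `c1ccc(CO/N=C2/C(c3c[nH]c4ccccc34)=Nc3ccccc32)cc1` gives 21400 nM
- Compound 2 `Cc1ccc(CO/N=C2/C(c3c[nH]c4ccccc34)=Nc3ccccc32)cc1` gives 25400 nM
- Compound 3 `Fc1ccc(CO/N=C2/C(c3c[nH]c4ccccc34)=Nc3ccccc32)cc1` gives 25900 nM

The numbers show a 1.2-fold higher number from compound 1 to compound 3 (0.08 log units; within the scatter) and a 1.0-fold higher number from compound 2 to compound 3 (0.01 log units; within the scatter), so compound 3 stands level with compound 1 and compound 2.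

Compound 4 `FC(F)(F)c1ccc(CO/N=C2/C(c3c[nH]c4ccccc34)=Nc3ccccc32)cc1` has trifluoromethyl in place of fluoro on an aromatic carbon, para to a large group (trifluoromethyl in place of fluoro on an aromatic carbon). Two measured changes at that same place bear on this. Methyl in place of hydrogen gave a 1.2-fold higher number from compound 1 to compound 2 (0.07 log units; within the scatter), and fluoro in place of hydrogen gave a 1.2-fold higher number from compound 1 to compound 3 (0.08 log units; within the scatter). Neither moved the number beyond the scatter. Among the measured compounds shown here, no measured compound carries trifluoromethyl, so the expectation is an extrapolation and the range is kept wide.

The expected change is a 1.0-fold lower number from compound 3 to compound 4 (0.02 log units; within the scatter), which means no step beyond the scatter is anticipated. For compound 4 the estimated value is 25000 nM, with an expected range from 14000 nM to 45000 nM.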

Compound 4, half-maximal inhibitory concentration: 21200 nM
Compound 4: the middle estimate sits 1.2-fold (0.07 log units) above what was measured; the range from low to high includes it.
By their numbers in this assay, from the lowest: compounds 4, 1, 2 and 3 (each within the scatter of the next).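

In this assay, among the compounds shown here, trifluoromethyl brings four heavy atoms to this place on the ring where fluoro brings one, yet the comparison with each earlier compound stays within the scatter: a 1.2-fold lower number from compound 3 to compound 4 (0.09 log units; within the scatter) and a 1.2-fold lower number from compound 2 to compound 4 (0.08 log units; within the scatter) and a 1.0-fold lower number from compound 1 to compound 4 (0.00 log units; within the scatter) all show no real step. The earlier compounds shown here covered only hydrogen, methyl and fluoro here, so compound 4 extends the set of groups that leave the number in the same narrow band to a larger one. Nothing measured here speaks to why these four compounds read alike.

As far as these compounds go, whether any group at this place can move the number beyond the scatter remains open. An amine, a carboxylic acid or a longer chain such as butyl would test this, since each differs in kind from the four groups shown.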